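Brain Free Fraction: Swapping Trifluoromethyl for Pyrimidin-2-yl

This account rests on a few compounds, and the source may have more. Where it says the series, first, only, none or still open, it means among the compounds named here.

Measured so far:
- compound 1, `O=C1O[C@]2(CC[C@H](CNc3cnn(-c4ccccc4F)c3)CC2)CN1c1ccnnc1`, 0.044
- compound 2, `O=C1O[C@]2(CC[C@H](CNc3ccc(C(F)(F)F)cn3)CC2)CN1c1ccccn1`, 0.005
- compound 3, `O=C1O[C@]2(CC[C@H](CNc3ncc(-c4ccccc4F)cn3)CC2)CN1c1ccccn1`, < 0.01

These three compounds share a core and were tested in an ADME assay on brain (Rattus norvegicus) for protein binding; on this read-out higher numbers stand for a larger free fraction and lower numbers for a smaller free fraction. Compound 1 gives 0.044. Compound 2 gives 0.005, the lowest of the two plain numbers, with compound 1 sitting above it by a margin beyond the usual scatter. Compound 3 returns only a limit of the assay, < 0.01, and not a number; this is the case described by the limit of < 0.01 in this assay, at which 1 of the 3 values shown sits.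

The step of interest leads from compound 2 to compound 4, `O=C1O[C@]2(CC[C@H](CNc3ccc(-c4ncccn4)cn3)CC2)CN1c1ccccn1`, not yet measured. The change is pyrimidin-2-yl in place of trifluoromethyl on an aromatic carbon. For the measured compounds named here, no measured pair in this set tests this exact change, so the direction rests on expectation alone.

Compound 4 is expected to give 0.012 in this assay, within a range from 0.004 to 0.035. The expected step is a 2.4-fold higher number from compound 2 to compound 4 (0.38 log units; beyond the scatter), a modest rise that may still fall inside the scatter.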

Compound 4, unbound fraction: 0.035
Beside the measured number, compound 4's estimate is 2.9-fold (0.46 log units) below it; low and high end bracket the measured number.
By their numbers in this assay, from the lowest: compound 2; then compounds 4 and 1 (each within the scatter of the next).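

In this assay, putting pyrimidin-2-yl in place of trifluoromethyl gives a 7.0-fold higher number from compound 2 to compound 4 (0.85 log units; beyond the scatter). For the compounds shown here, this is the first pair in the set that differs in one place, and it shows that the group on this aromatic carbon, two atoms from the ring nitrogen, can shift the free fraction in brain by more than the usual scatter. The larger entering group, with its six-membered aromatic ring and hydrogen-bond acceptors, goes with a larger free fraction here, not a smaller one, although this rests on a single pair.

Compound 3 offers no further comparison, as it gives only a limit of the assay: the limit of < 0.01 in this assay, at which 1 of the 4 values shown sits.

From the compounds shown here alone, one pair cannot separate the effect of the added ring from that of its nitrogens, and whether a small group at this place, such as a nitrile or an amine, would shift the free fraction in the same direction remains open.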